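Methoxy Added on the Pendant Phenyl: Expected Cytotoxicity

The source may report more compounds than this note shows. Statements on the series, on what has been measured and on what is new or still open speak of the compounds shown alone.

Measured compounds:
compound 1 `COc1ccc(-c2cc(-c3ccc4cc(F)ccc4n3)n(-c3ccccc3)n2)cc1`: 104%
compound 2 `COc1ccc(-n2nc(-c3ccccc3)cc2-c2ccc3cc(F)ccc3n2)cc1`: 116%

In an ADME assay on Huh-7 cells (Homo sapiens) for cytotoxicity, read by XTT assay, with a stated time of 3 days, tested at 20 uM (a lower number here means a stronger effect, a higher number a weaker effect of the compound at the concentration tested), compound 1 gives 104% and compound 2 gives 116%, the higher of the two numbers, a gap beyond the usual scatter. Compound 3 `COc1ccc(-c2cc(-c3ccc4cc(F)ccc4n3)n(-c3ccc(OC)cc3)n2)cc1` has not yet been measured. It differs from compound 2 in one place: methoxy in place of hydrogen on an aromatic carbon. Because compound 2 gives 116%, a weak effect at this concentration, no step beyond the scatter is expected in this assay. The expected step is a number 8 percentage points lower from compound 2 to compound 3 (within the scatter). Compound 3 is therefore estimated at 108%, with a range from 92% to 124%.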

Compound 3, a percentage reported as activity, at one concentration (the size of the read-out at that concentration, not a potency): 95.8%
Estimate against measurement, compound 3: 12.2 percentage points above, within the range that was stated.
By their numbers in this assay, from the lowest: compounds 3 and 1 (each within the scatter of the next); then compound 2.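

In this assay, the phenyl to 4-methoxyphenyl change can now be read on two different phenyl rings of the shared core. Adding methoxy gives a number 20.2 percentage points lower from compound 2 to compound 3 (beyond the scatter) on one ring and a number 8.2 percentage points lower from compound 1 to compound 3 (within the scatter) on the other, so the size of this step depends on which ring receives the group. Nothing available explains that difference.

As far as these compounds go, whether an amine or a carboxylic acid at the same place would shift the read-out remains open. So does whether either ring would respond similarly to a longer chain.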